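Selenium in place of sulfur on the shared core

This account rests on a few compounds, and the source may have more. Where it says the series, first, only, none or still open, it means among the compounds named here.

For the measured compounds named here, compound 1 `CS/C(=N\C(=O)c1sccc1Cl)NC(=O)c1sccc1Cl` is the one member of the set with a methylsulfanyl group on the central carbon; in a functional assay on HepG2 cells (Homo sapiens) for cytotoxicity, read by MTT assay, with a stated time of 72 h (on this read-out higher numbers stand for weaker inhibition of growth and lower numbers for stronger inhibition of growth), compound 1 gives 65300 nM. Compound 2 `C[Se]/C(=N\C(=O)c1ccco1)NC(=O)c1ccco1` gives 760 nM and compound 3 `C[Se]/C(=N\C(=O)c1ccno1)NC(=O)c1ccno1` gives 510 nM. Compound 1 therefore stands at the highest number of the three, with compound 2 nearest and compound 3 furthest, and both gaps lie beyond the scatter. Going by the values given here, compounds 2 and 3 carry a methyl on selenium rather than on sulfur, but they also carry other aryl amide parts than compound 1, so no measured pair isolates a single change.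

Compound 4 `C[Se]/C(=N\C(=O)c1sccc1Cl)NC(=O)c1sccc1Cl` is the unmeasured analogue. Relative to compound 1 the difference is a group of 2 heavy atoms (1 carbon, 1 selenium; no ring) in place of a group of 2 heavy atoms (1 carbon, 1 sulfur; no ring), on a carbon with a double bond to nitrogen. As far as these compounds go, the two measured compounds that carry the entering group sit far below compound 1, yet the change of the aryl parts is not separated from the change at the central carbon, so the size of the step remains open. A downward step is expected, a 22-fold lower number from compound 1 to compound 4 (1.34 log units; beyond the scatter), larger than the scatter but smaller than the gaps to compound 2 and compound 3. Compound 4 is estimated at 3000 nM, with a range from 500 nM to 20000 nM.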

Compound 4, concentration for 50% growth inhibition: 690 nM
The estimate for compound 4 lay 4.3-fold (0.64 log units) above the measured number; low and high end bracket the measured number.
By their numbers in this assay, from the lowest: compounds 3, 4 and 2 (each within the scatter of the next); then compound 1.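

For the compounds shown here, compound 4 gives the first single-place reading at this carbon: with the aryl amide parts held fixed, placing the methyl on selenium instead of sulfur gives a 95-fold lower number from compound 1 to compound 4 (1.98 log units; beyond the scatter) in this assay, a large step from this one exchange alone. Going by these compounds alone, the three selenium compounds now lie within the scatter of one another even though their aryl amide parts differ, so the high number of compound 1 stands apart as that of the sole methylsulfanyl member of the set. Nothing among the available data accounts for the size of this step or links it to any property of the group.

Whether a step of this size also holds with the aryl amide parts of compound 2 and compound 3 remains open, as the sulfur counterparts of those two compounds do not appear in the series as shown. Also open, as far as these compounds go, is how the number responds when the methyl on selenium gives way to a longer chain such as ethyl or benzyl, or when an amine takes the place of the whole group on this carbon.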